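A few compounds are considered here, and "the series" means these few. Any claim that something is new, unique, unknown or untested is made for them only; others in the source may bear on it.

Measured so far in a functional assay on PC-9 cells (Homo sapiens) for inhibition, read by MTT assay, with a stated time of 48 h, tested at 10 uM; a higher number here means more inhibition at the concentration tested (going by the name of the read-out), a lower number less inhibition: compound 1 `Cc1ccc(Nc2cc(NC(=O)Nc3c(Cl)cccc3Cl)ncn2)cc1F` gives 92%; compound 2 `COc1ccc(F)cc1Nc1cc(NC(=O)Nc2c(Cl)cccc2Cl)ncn1` gives 85.5%; compound 3 `COc1cc(NC(=O)Nc2cc(Nc3ccc(C)c(C)c3)ncn2)cc(OC)c1` gives 66%.

Compound 2 stands second highest of these three. Its nearest neighbour is compound 1, and the step of a number 6.5 percentage points lower from compound 1 to compound 2 (within the scatter) is within the scatter, so the two cannot be ranked against each other. Compound 3 lies further off, beyond the scatter, on the lower side.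

Compound 4 `Cc1cc(F)cc(Nc2cc(NC(=O)Nc3c(Cl)cccc3Cl)ncn2)c1` has not yet been measured. It differs from compound 2 in one place: 3-fluoro-5-methylphenyl in place of 5-fluoro-2-methoxyphenyl on a nitrogen on an aromatic ring. Among the measured compounds shown here, the only measured step that touches this position is a number 6.5 percentage points lower from compound 1 to compound 2 (within the scatter), where one fluoro-methyl-substituted phenyl replaced another and the number stayed within the scatter. Compound 4 carries a phenyl of the same kind, so no step beyond the scatter is expected; the expected step is a number 2.5 percentage points higher from compound 2 to compound 4 (within the scatter). Compound 4 is estimated at 88%, with a range from 75% to 97%.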

Compound 4, a percentage reported as inhibition, at one concentration (the size of the read-out at that concentration, not a potency): 80%
For compound 4 the middle estimate is 8 percentage points above the measured one, within the range that was stated.
By their numbers in this assay, from the lowest: compound 3; then compounds 4, 2 and 1 (each within the scatter of the next, the first and the last beyond it).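

In this assay, among the compounds shown here, 3-fluoro-5-methylphenyl in place of 3-fluoro-4-methylphenyl gives a number 12 percentage points lower from compound 1 to compound 4 (beyond the scatter), the first step at this position that passes the scatter, so two phenyl groups carrying the same fluoro and methyl substituents in different places need not read alike. Replacing 5-fluoro-2-methoxyphenyl with 3-fluoro-5-methylphenyl gives only a number 5.5 percentage points lower from compound 2 to compound 4 (within the scatter). Nothing measured here offers an explanation for either step. The compounds shown leave open how this position would respond to a phenyl ring carrying an amine or a carboxylic acid.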